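The compounds below may be only part of what the source reports. "The series", "measured", "known", "first", "only" and "open" are said of these compounds alone.

Values in a functional assay on DU-145 cells (Homo sapiens) for cytotoxicity, read by ELISA, with a stated time of 4 days (a lower number here means a stronger inhibitor, a higher number a weaker inhibitor), for the series:
- compound 1 `Cc1ccsc1-c1cc(-c2ccco2)cc(-c2ccccc2Cl)n1` gives 29900 nM 
- compound 2 `Cc1ccsc1-c1cc(-c2ccco2)cc(-c2ccc(Cl)cc2)n1` gives 26700 nM 
- compound 3 `Clc1ccc(-c2cc(-c3ccco3)cc(-c3ccc(Cl)s3)n2)cc1` gives 14800 nM 

Compound 2 lies within the scatter of both compound 1 and compound 3, so its two measured steps give no ranking around it. The next compound is compound 4 `Cc1ccsc1-c1cc(-c2ccc(Cl)o2)cc(-c2ccc(Cl)cc2)n1` and it differs from compound 2 on the furan: chloro in place of hydrogen on an aromatic carbon with the group going from furan-2-yl to 5-chlorofuran-2-yl. For the measured compounds named here, no measured step touches this group. The nearest in kind is a 1.8-fold lower number from compound 2 to compound 3 (0.26 log units; within the scatter) and it brings in a chloro on a different ring, as 5-chlorothiophen-2-yl in place of 3-methylthiophen-2-yl. The other is a 1.1-fold lower number from compound 1 to compound 2 (0.05 log units; within the scatter) and it concerns only the chlorophenyl group. With both of these small, no step beyond the scatter is expected in this assay and any shift is expected to be toward a lower number. The estimated step is a 1.3-fold lower number from compound 2 to compound 4 (0.13 log units; within the scatter) and this remains a weak expectation. For compound 4 the estimated value is 20000 nM (expected range 9000 nM to 40000 nM) in this assay.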

Compound 4, half-maximal inhibitory concentration: 21900 nM
For compound 4 the middle estimate is 1.1-fold (0.04 log units) below the measured one, within the range that was stated.
By their numbers in this assay, from the lowest: compounds 3, 4, 2 and 1 (each within the scatter of the next, the first and the last beyond it).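

Chloro in place of hydrogen on the furan, on the aromatic carbon next to the ring oxygen, gives a 1.2-fold lower number from compound 2 to compound 4 (0.09 log units; within the scatter) in this assay, and this is the only change to the furan among the compounds shown. Compounds 1, 2 and 3 differ only in the chlorophenyl and thiophene groups, so they said nothing about this position; it now carries a chloro with no step beyond the scatter in this assay. No measurement at hand bears on the reason for this result.

Going by these compounds, whether an amine, a carboxylic acid or a longer alkyl chain at this position would give a step beyond the scatter remains open. Also open, on these data alone, is whether 5-chlorofuran-2-yl would read the same alongside the 5-chlorothiophen-2-yl group of compound 3.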